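Sulfonyl for nitrobenzyl on the ring nitrogen

This account rests on a few compounds, and the source may have more. Where it says the series, first, only, none or still open, it means among the compounds named here.

In an assay on isolated protein with dual specificity calcium/calmodulin-dependent 3',5'-cyclic nucleotide phosphodiesterase 1B (Bos taurus) as the target, tested at 100 uM (on this read-out lower numbers stand for less inhibition and higher numbers for more inhibition at the one concentration tested (going by the name of the read-out)), compound 3 `Nc1nc2c(c(=O)n(CC3CC3)c(=O)n2CC2CC2)n1Cc1ccc([N+](=O)[O-])cc1` gives 30%, the second highest of three numbers. Compound 1 `Nc1nc2c(c(=O)n(CC3CC3)c(=O)n2CC2CC2)n1Cc1ccccc1` gives 27%; a number 3 percentage points higher from compound 1 to compound 3 (within the scatter), within the scatter. Compound 2 `COc1ccc(Cn2c(N)nc3c2c(=O)n(CC2CC2)c(=O)n3CC2CC2)cc1` gives 60%; a number 33 percentage points higher from compound 1 to compound 2 (beyond the scatter), and a number 30 percentage points lower from compound 2 to compound 3 (beyond the scatter). Compound 4 `Nc1nc2c(c(=O)n(CC3CC3)c(=O)n2CC2CC2)n1S(=O)(=O)c1ccccc1` carries phenylsulfonyl in place of 4-nitrobenzyl on an aromatic nitrogen. Among the compounds with values here, no measured step replaces the whole group on this ring nitrogen; only its substituent varied, and nitro for hydrogen stayed within the scatter while methoxy gave a modest gain. Within the data shown here, a phenylsulfonyl has no precedent, so for compound 4 the expected step is a number 2 percentage points lower from compound 3 to compound 4 (within the scatter), near zero with a wide range. For compound 4 the estimate in this assay is 28%, between 5% and 55%.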

Compound 4, a percentage reported as inhibition, at one concentration (the size of the read-out at that concentration, not a potency): 13%
Beside the measured number, compound 4's estimate is 15 percentage points above it; measured number inside the range.
By their numbers in this assay, from the lowest: compound 4; then compounds 1 and 3 (each within the scatter of the next); then compound 2.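

In this assay exchanging the whole group on the ring nitrogen, not only a substituent on it, gives a number 17 percentage points lower from compound 3 to compound 4 (beyond the scatter) and likewise a number 14 percentage points lower from compound 1 to compound 4 (beyond the scatter) while the gap from the methoxy compound is a number 47 percentage points lower from compound 2 to compound 4 (beyond the scatter) in this series. Phenylsulfonyl therefore stands below all three benzyl groups, so the group attached to this nitrogen matters in a way the nitro-for-hydrogen step did not reveal. Nothing available explains the drop.

Open, from the compounds shown here alone, is whether methoxy on the phenylsulfonyl ring brings a gain like the one seen on the benzyl. Also open, going by these compounds, is whether a methylsulfonyl or an acetyl on this nitrogen lands near compound 4.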